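Nitro for a third side chain on a triply substituted core

A few compounds are considered here, and "the series" means these few. Any claim that something is new, unique, unknown or untested is made for them only; others in the source may bear on it.

Compound 1 `O=C(NCCCNC1CCCCC1)c1ccc(CNCCCNC2CCCCC2)cc1`: 699 nM
Compound 2 `c1c(CNCCCNC2CCCCC2)cc(CNCCCNC2CCCCC2)cc1CNCCCNC1CCCCC1`: 312 nM
Compound 3 `O=[N+]([O-])c1cc(CNCCCNC2CCCCC2)ccc1CNCCCNC1CCCCC1`: 354 nM

The three measured compounds were tested in an assay on CHO cells for displacement of a labelled ligand from C-X-C chemokine receptor type 4 (Homo sapiens), with a stated time of 40 min; on this read-out lower numbers stand for stronger inhibition and higher numbers for weaker inhibition. Compound 2 gives 312 nM, the lowest of the three numbers. Compound 3, which also carries a nitro group beside the same cyclohexylamino-propylamino-methyl side chains, gives 354 nM, a value that lies within the usual scatter of that of compound 2. Compound 1, which links one side chain through an amide instead of a methylene, gives 699 nM, which is beyond the scatter above compound 2.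

Compound 4 `O=[N+]([O-])c1cc(CNCCCNC2CCCCC2)cc(CNCCCNC2CCCCC2)c1` has not yet been measured in this assay. It differs from compound 2 by nitro in place of ((3-(cyclohexylamino)propyl)amino)methyl on an aromatic carbon. Because compound 3 gives 354 nM with a nitro group and the same side chains, compound 4 is expected to land close to compounds 2 and 3 rather than near compound 1. Going by the values given here, no step between measured compounds is available for this exact change, so the expected step from compound 2 to compound 4 is estimated as a small rise, probably within the scatter or just beyond it, at a 1.4-fold higher number from compound 2 to compound 4 (0.16 log units; within the scatter). Compound 4 is therefore estimated at 450 nM, in a range from 200 nM to 1000 nM.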

Compound 4, half-maximal inhibitory concentration: 147 nM
Compound 4: middle estimate off by 3.1-fold (0.49 log units), on the high side; the measured number lies below the stated range.
By their numbers in this assay, from the lowest: compound 4; then compounds 2, 3 and 1 (each within the scatter of the next, the first and the last beyond it).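

In this assay, the third ((3-(cyclohexylamino)propyl)amino)methyl group on the shared core proves dispensable at this aromatic carbon, meta to the two groups of that name that remain: nitro in its place gives a 2.1-fold lower number from compound 2 to compound 4 (0.33 log units; beyond the scatter) as a modest step in favour of the smaller substituent. Going by these compounds alone, this is the first direct one-place comparison, and it shows that a group with a six-membered non-aromatic ring and 2 hydrogen-bond donors can give way to nitro, with no ring and 0 hydrogen-bond donors, without any loss on this read-out. No measurement presented here accounts for the lower number, so the reason for the step remains unknown.

The comparison cannot separate what nitro contributes from what is gained by losing the side chain, since both happen in the same exchange. Going by these compounds, whether a plain hydrogen, a nitrile, a carboxylic acid or a primary amine on the same aromatic carbon would match, exceed or fall short of nitro remains open, as does whether a shorter chain there would be tolerated.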